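Compound 4: ethoxy in place of methyl, an estimate

The source may hold more compounds than are shown below. What is called first, only, known or untested is meant among the compounds shown, and "the series" means these compounds.

compound 1 `O=C1C(NC2CCCC2)=CC(=O)c2c1nc1n2[C@H]2OC[C@@H](O)[C@H]2OC1`: > 16000 nM (a limit)
compound 2 `Cc1ccc(NC2=CC(=O)c3c(nc4n3[C@H]3OC[C@@H](O)[C@H]3OC4)C2=O)cc1`: > 4000 nM (a limit)
compound 3 `O=C1C(N2CCC2)=CC(=O)c2c1nc1n2[C@H]2OC[C@@H](O)[C@H]2OC1`: > 16000 nM (a limit)

For the measured compounds named here, every value so far in a functional assay on ECa-109 cells for inhibition, with ECa-109 cell line (Homo sapiens) as the target, read by sulforhodamine B assay (on this read-out higher numbers stand for weaker inhibition and lower numbers for stronger inhibition), is a limit and not a number. Compound 2 stands only at > 4000 nM as a limit. Compound 4 `CCOc1ccc(NC2=CC(=O)c3c(nc4n3[C@H]3OC[C@@H](O)[C@H]3OC4)C2=O)cc1` is the next to be read. The counted difference ethoxy in place of methyl on an aromatic carbon is ethoxy in place of methyl on an aromatic carbon, para to a large group. The steps a step that the two limits leave unreadable from compound 1 to compound 2 and a step that the two limits leave unreadable from compound 2 to compound 3 bear on it and show no readable size. Compound 2 at > 4000 nM gives no direction, so no step beyond the scatter is expected. The expected step that the limit leaves unreadable from compound 2 to compound 4 is an estimate only. Compound 4 is estimated at 6000 nM with 2000 nM to 16000 nM as its expected range.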

Compound 4, half-maximal inhibitory concentration: > 4000 nM
Compound 4 was reported as a limit; the forecaster's own chance of this, stated with the estimate: 65%; the middle value does not contradict the limit.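

Compound 4 is reported only as a limit, as are compound 1 and compound 2, so neither step to compound 4 can be read. The compounds shown leave open whether ethoxy in place of methyl changes inhibition at all.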